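From cyclobutyl to cyclopentyl on an aromatic nitrogen

A few compounds are considered here, and "the series" means these few. Any claim that something is new, unique, unknown or untested is made for them only; others in the source may bear on it.

In a functional assay on HT-29 cells (Homo sapiens) for inhibition, read by luminescence and CellTiter-Glo, with a stated time of 24 h (on this read-out higher numbers stand for an effect only at larger amounts of compound and lower numbers for an effect already at smaller amounts), compound 1 (`CCn1nc(C(=O)N[C@H]2COc3ccccc3N(C)C2=S)nc1Cc1ccccc1`) gives 17 nM and compound 2 (`CN1C(=S)[C@@H](NC(=O)c2nc(Cc3ccccc3)n(C3CCC3)n2)COc2ccccc21`) gives 181 nM as the higher of the two numbers. Compound 3 (`CN1C(=S)[C@@H](NC(=O)c2nc(Cc3ccccc3)n(C3CCCC3)n2)COc2ccccc21`), not yet measured, carries cyclopentyl in place of cyclobutyl on an aromatic nitrogen. Among the compounds with values here, the one measured step at this nitrogen, cyclobutyl in place of ethyl, is an 11-fold higher number from compound 1 to compound 2 (1.03 log units; beyond the scatter) and is large, so a further, smaller rise in this assay is expected. The expected change is a 2.2-fold higher number from compound 2 to compound 3 (0.34 log units; beyond the scatter) and rests on that single step. For compound 3 the estimate is 400 nM with an expected range of 100 nM to 1500 nM in this read-out.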

Compound 3, half-maximal effective concentration: 3530 nM
For compound 3 the middle estimate is 8.8-fold (0.95 log units) below the measured one; measured number above the stated range.
By their numbers in this assay, from the lowest: compound 1; then compound 2; then compound 3.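

In this assay, cyclopentyl in place of cyclobutyl on the aromatic nitrogen gives a 20-fold higher number from compound 2 to compound 3 (1.29 log units; beyond the scatter) and so shows that even this change of ring size alone produces a large step. Taken together with ethyl, the overall change is a 210-fold higher number from compound 1 to compound 3 (2.32 log units; beyond the scatter) and the numbers rise in the order ethyl, cyclobutyl, cyclopentyl, with none of the three compounds going against that order. No evidence is available that bears on this result.

From the compounds shown here alone, it remains open whether cyclohexyl would continue the rise. A propyl chain or a ring carrying an amine at this nitrogen is also untested among the compounds shown, so its place relative to ethyl remains unknown.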